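The compounds below may be only part of what the source reports. "The series", "measured", "known", "first", "only" and "open" are said of these compounds alone.

Of the compounds shown here, three have so far been tested in a functional assay on the whole organism (Ehrlich cells, Mus musculus) for antiproliferative activity, with a stated time of 24 h, at a dose of 0.2 mmol/kg by the intraperitoneal route; on this read-out higher numbers stand for more inhibition at the one dose given (going by the name of the read-out) and lower numbers for less inhibition. Compound 1, `Nc1ccccc1NC(=O)CCCNCC(=O)Nc1cccc(Cl)c1`, gives 32.1%. Compound 2, `Nc1ccccc1NC(=O)CCCNCC(=O)Nc1ccc(Br)cc1`, gives 73.8%. Compound 3, `Nc1ccccc1NC(=O)c1ccc(NCC(=O)Nc2ccc([N+](=O)[O-])cc2)cc1`, gives 83.3%. Compound 3 and compound 2 thus fall within the scatter of each other, and neither can be called stronger than the other; compound 1 lies clearly below both of them.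

Compound 4, `Nc1ccccc1NC(=O)c1ccc(NCC(=O)Nc2cccc([N+](=O)[O-])c2)cc1`, differs from compound 3 in a single place: 3-nitrophenyl in place of 4-nitrophenyl on an amide-type nitrogen. The same atoms are present, joined differently.

Going by the values given here, the only measured step that touches on moving a ring substituent in this way is a number 41.7 percentage points higher from compound 1 to compound 2 (beyond the scatter). Among the compounds with values here, that step, however, also swaps one halogen for another and sits on a different core, so it is at best a loose guide, and no step compares a 4-nitrophenyl with a 3-nitrophenyl directly. Taken at face value, it hints that moving the group as in compound 4 may cost some inhibition in this assay, and the estimate is therefore a moderate drop, a number 21.3 percentage points lower from compound 3 to compound 4 (beyond the scatter), with wide uncertainty because only a number 41.7 percentage points higher from compound 1 to compound 2 (beyond the scatter) informs it.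

For compound 4 the expected result in this assay is 62%, in a range from 38% to 84%.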

Compound 4, a percentage reported as inhibition, in the whole organism at one dose (the size of the read-out at that dose, not a potency): 67.6%
For compound 4 the middle estimate is 5.6 percentage points below the measured one, and the stated range covers the measured number.
By their numbers in this assay, from the lowest: compound 1; then compounds 4, 2 and 3 (each within the scatter of the next, the first and the last beyond it).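

In this assay, 3-nitrophenyl in place of 4-nitrophenyl on an amide-type nitrogen gives a number 15.7 percentage points lower from compound 3 to compound 4 (beyond the scatter), so the place of the nitro group on this ring matters even though both compounds hold the same atoms. The earlier step, a number 41.7 percentage points higher from compound 1 to compound 2 (beyond the scatter), changed the halogen and its place together, whereas here the place alone differs, and the loss is only partial, since compound 4 still gives 67.6%. No measurement available here explains why this change lowers the inhibition.

The compounds shown leave open whether a similar loss would follow on moving another group on this ring, such as a nitrile or a carboxylic acid, and whether the nitro move would act the same way on the core of compound 1. They also leave open how far this step would hold at other doses, as each number is the size of the effect at one dose and not a potency.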